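The source may hold more compounds than are shown below. What is called first, only, known or untested is meant among the compounds shown, and "the series" means these compounds.

- compound 1 `Cc1ccc(-c2nnc(SCCCN3CCN(c4nc5ccccc5o4)CC3)o2)cc1`: 106000 nM
- compound 2 `O=C(NCc1nnc(SCCCN2CCN(c3nc4ccccc4o3)CC2)o1)c1ccccc1`: 102000 nM
- compound 3 `Cc1ccc(-c2nnc(SCCCN3CCN(c4nc5ccccc5s4)CC3)o2)cc1`: 53900 nM
- compound 4 `CC(C)(C)Oc1ccc(-c2nnc(SCCCN3CCN(c4nc5ccccc5s4)CC3)o2)cc1`: not yet measured

These values come from a functional assay on A549 cells (Homo sapiens) for inhibition, read by MTT assay, with a stated time of 72 h; on this read-out higher numbers stand for weaker inhibition and lower numbers for stronger inhibition. There, compound 3 gives 53900 nM, which lies within the usual scatter of the values for the other two compounds, so the three cannot be ranked.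

Compound 4 differs from compound 3 by one change, tert-butoxy in place of methyl on an aromatic carbon.

Two measured steps offer some guidance. The nearer one is a 1.0-fold lower number from compound 1 to compound 2 (0.02 log units; within the scatter), which also removes the 4-methylphenyl group, replacing it with benzamidomethyl. The other is a 2.0-fold lower number from compound 1 to compound 3 (0.29 log units; within the scatter), a change elsewhere in the molecule. Both stay within the scatter, but neither tests tert-butoxy itself, so the evidence is thin and no step beyond the scatter is expected in this assay.

The step expected is a 1.2-fold lower number from compound 3 to compound 4 (0.08 log units; within the scatter).

The estimate for compound 4 is 45000 nM, with an expected range of 18000 nM to 105000 nM.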

Compound 4, half-maximal inhibitory concentration: 71600 nM
Compound 4: the middle estimate sits 1.6-fold (0.20 log units) below what was measured; low and high end bracket the measured number.
By their numbers in this assay, from the lowest: compounds 3, 4, 2 and 1 (each within the scatter of the next).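

In this assay, the swap of methyl for tert-butoxy gives a 1.3-fold higher number from compound 3 to compound 4 (0.12 log units; within the scatter), and this is the first step shown that keeps the six-membered aromatic ring and changes only the group on it. Tert-butoxy brings 5 heavy atoms and 1 hydrogen-bond acceptor where methyl had 1 heavy atom and no acceptor, yet the assay does not separate compound 3 from compound 4, so this position accepts the larger group with no readable change. Nothing available explains this result.

Going by these compounds, it remains open whether a different group at this position, such as an amine or a carboxylic acid, would give a step beyond the scatter. Also open, on these data alone, is whether tert-butoxy would behave the same way with 1,3-benzoxazol-2-yl in place of 1,3-benzothiazol-2-yl.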